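The compounds below may be only part of what the source reports. "The series", "measured", "known", "first", "only" and "open" are said of these compounds alone.

Measured in a functional assay (aorta) with Rattus norvegicus as the target; on this read-out lower numbers stand for stronger inhibition and higher numbers for weaker inhibition:
- Compound 1 `CC1(C)Oc2ccc(C#N)cc2[C@@H](/N=C(\NC#N)Nc2ccc(Cl)cc2)[C@@H]1O`: 1800 nM
- Compound 2 `CC1(C)Oc2ccc(C#N)cc2[C@@H](/N=C(\NC#N)Nc2ccccc2)[C@@H]1O`: 1400 nM; 1300 nM (2 entries)
- Compound 3 `CC1(C)Oc2ccc(C#N)cc2[C@@H](/N=C(\NC#N)NCc2ccccc2)[C@@H]1O`: 2400 nM

Compound 3, at 2400 nM, cannot be separated from compound 1, as the step shows: a 1.3-fold higher number from compound 1 to compound 3 (0.12 log units; within the scatter). the several entries of compound 2 in this assay, 1400 nM; 1300 nM (2 entries) sit close together, so repeat readings agree well here.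

Compound 4 `CC1(C)Oc2ccc(C#N)cc2[C@@H](/N=C(\NC#N)Nc2ccc(N)cc2)[C@@H]1O` carries 4-aminophenyl in place of benzyl on an amine nitrogen. Among the measured compounds shown here, only one measured step swaps a group at this place, and it stayed within the scatter: a 1.3-fold higher number from compound 1 to compound 3 (0.12 log units; within the scatter). On that single step, no change beyond the scatter is expected in this assay, and the expected step is a 1.3-fold lower number from compound 3 to compound 4 (0.12 log units; within the scatter). The estimated value for compound 4 is 1800 nM, with a range from 800 nM to 4000 nM.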

Compound 4, half-maximal inhibitory concentration: 3500 nM
Compound 4: the middle estimate sits 1.9-fold (0.29 log units) below what was measured; the measured number falls inside the stated range.
By their numbers in this assay, from the lowest: compounds 1, 3 and 4 (each within the scatter of the next).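

Amino, a group with a hydrogen-bond donor, now replaces chloro on an aromatic carbon, and in this assay this swap stays within the scatter (a 1.9-fold higher number from compound 1 to compound 4 (0.29 log units; within the scatter)). Replacing benzyl with 4-aminophenyl on the amine nitrogen does the same (a 1.5-fold higher number from compound 3 to compound 4 (0.16 log units; within the scatter)), so three different groups at this place now cannot be told apart. Among the compounds shown here, nothing measured so far bears on why these groups read alike. Still open, as far as these compounds go, is whether a carboxylic acid on the aromatic ring, or a longer chain on the amine nitrogen, would shift the number beyond the scatter.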